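A few compounds are considered here, and "the series" means these few. Any claim that something is new, unique, unknown or untested is made for them only; others in the source may bear on it.

Measured compounds:
Compound 1 `O=C(Nc1cccc([N+](=O)[O-])c1)N[C@H]1CC[C@H](Oc2ccc(F)cc2)CC1` gives 6700 nM.
Compound 2 `O=C(Nc1ccc(Cl)cc1)N[C@H]1CC[C@H](Oc2ccc(F)cc2)CC1` gives > 20000 nM, which is a limit of the assay.
Compound 3 `CSc1ccccc1NC(=O)N[C@H]1CC[C@H](Oc2ccc(F)cc2)CC1` gives > 20000 nM, also a limit of the assay.

Among the measured compounds shown here, in a functional assay on CRL2813 cells (Homo sapiens) for cytotoxicity, read by sulforhodamine B assay, with a stated time of 5 days (on this read-out higher numbers stand for weaker inhibition and lower numbers for stronger inhibition), compound 1 stands as the only compound with an actual number; the other two values are limits. The step of an at least 2.9-fold higher number from compound 1 to compound 2 (0.47 log units; beyond the scatter) and the step of an at least 2.9-fold higher number from compound 1 to compound 3 (0.47 log units; beyond the scatter) both replace the 3-nitrophenyl group and both end at the limit (the limit of > 20000 nM in this assay, at which 2 of the 3 values shown sit). The step that the two limits leave unreadable from compound 2 to compound 3 cannot be sized.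

Compound 4 `COC(=O)c1cccc(NC(=O)N[C@H]2CC[C@H](Oc3ccc(F)cc3)CC2)c1` differs from compound 1 by methoxycarbonyl in place of nitro on an aromatic carbon. For the measured compounds named here, no measured step exchanges only the nitro group for another substituent, and no measured step keeps a group in the same position on that ring. Both known departures from the 3-nitrophenyl group were weakening, so a modest weakening is expected for compound 4 as well, with a real chance that only a limit is reported. Compound 4 is therefore expected to give 15000 nM, in the range 5000 nM to 40000 nM. This estimate corresponds to an expected step of a 2.2-fold higher number from compound 1 to compound 4 (0.35 log units; beyond the scatter).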

Compound 4, half-maximal inhibitory concentration: 9200 nM
Beside the measured number, compound 4's estimate is 1.6-fold (0.21 log units) above it, and the stated range covers the measured number.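

In this assay, methoxycarbonyl in place of nitro on the aromatic carbon gives a 1.4-fold higher number from compound 1 to compound 4 (0.14 log units; within the scatter), so the two groups cannot be told apart on this read-out. This is the first step shown that keeps the substituent in the same place, meta to a large group, and exchanges only the group itself. The nitro group is therefore not alone in giving a readable number here, since compound 4 gives 9200 nM. Compound 2 and compound 3 each reach only a limit of the assay: the limit of > 20000 nM in this assay, at which 2 of the 4 values shown sit.

Going by these compounds, whether nitro or methoxycarbonyl would read the same at another place on the ring stays open. Also open, on these data alone, is how an amine or a carboxylic acid would read in this same place, and whether any group there moves the number beyond the scatter from that of compound 1.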